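This account rests on a few compounds, and the source may have more. Where it says the series, first, only, none or still open, it means among the compounds named here.

Of the compounds shown here, three have been measured in an assay on isolated protein for inhibition of serine/threonine-protein kinase TNNI3K (Homo sapiens); a higher number here means a weaker inhibitor, a lower number a stronger inhibitor. Compound 1 `CNc1cc(Oc2ccc(NC(=O)Nc3cccc(CF)c3)cc2)ncn1` gives 400 nM. Compound 2 `O=C(Nc1ccc(Oc2cc(O)ncn2)cc1)Nc1cccc(C(F)(F)F)c1` gives 3200 nM, the highest of the three numbers; the value of compound 1 lies below it by a gap beyond the usual scatter. Compound 3 `CNc1cc(Oc2c(F)cc(NC(=O)Nc3cccc(C(F)(F)F)c3)cc2F)ncn1` gives 20 nM, and that value lies furthest below the value of compound 2, again well beyond the scatter. Compound 2 thus stands as the weakest inhibitor of the three.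

Compound 4 `C[C@H](O)CNc1cc(Oc2ccc(NC(=O)Nc3cccc(C(F)(F)F)c3)cc2)ncn1` is not yet measured. It differs from compound 2 in one place: (2-hydroxypropyl)amino in place of hydroxy on an aromatic carbon. Compounds 1 and 3 both carry an amino substituent at the same place and both give lower numbers than compound 2, so the account expects a sizeable step toward a lower number from compound 2 to compound 4, beyond the scatter, of about a 13-fold lower number from compound 2 to compound 4 (1.11 log units; beyond the scatter). On that basis compound 4 is estimated at 250 nM in this assay, with a range from 60 nM to 1000 nM.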

Compound 4, half-maximal inhibitory concentration: 32 nM
For compound 4 the middle estimate is 7.8-fold (0.89 log units) above the measured one, outside the stated range (below it).
By their numbers in this assay, from the lowest: compounds 3 and 4 (each within the scatter of the next); then compound 1; then compound 2.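

In this assay, going by these compounds alone, the change from hydroxy to (2-hydroxypropyl)amino brings a 100-fold lower number from compound 2 to compound 4 (2.00 log units; beyond the scatter) with nothing else altered, so this is the first reading of this position on its own; compounds 1 and 3 differ from compound 2 in more than one place. It shows that the aromatic carbon next to the ring nitrogen accepts this chain, with its defined stereocentre, and that the group at this one place can by itself move the number far beyond the scatter. Nothing shown here accounts for the size of this step.

Still open, from the compounds shown here alone, is which part of the chain carries the step: whether a plain amine or a propylamino chain without the hydroxy at the same place would give a similar number. Also open, going by these compounds, is how the mirror-image form of the (2-hydroxypropyl)amino chain would compare with compound 4.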